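Shortening the hexyloxy chain of compound 3 and adding an ether oxygen

The compounds below may be only part of what the source reports. "The series", "measured", "known", "first", "only" and "open" are said of these compounds alone.

Of the compounds shown here, three have been measured in a functional assay for inhibition of Vanilloid receptor (Rattus norvegicus); a higher number here means a weaker inhibitor, a lower number a stronger inhibitor. Compound 1 `Cc1cc(CN/C(S)=N/Cc2ccc(NS(C)(=O)=O)cc2)c(COC(=O)C(C)(C)C)cc1C` gives 70000 nM; compound 2 `COc1cc(C(C)(C)C)ccc1C/N=C(\S)NCc1ccc(NS(C)(=O)=O)cc1` gives 2400 nM; compound 3 `CCCCCCOc1cc(C(C)(C)C)ccc1C/N=C(\S)NCc1ccc(NS(C)(=O)=O)cc1` gives 150 nM, the lowest of the three numbers. Among the measured compounds shown here, the only measured change at a single place is a 16-fold lower number from compound 2 to compound 3 (1.20 log units; beyond the scatter). Compound 4 `COCCOc1cc(C(C)(C)C)ccc1C/N=C(\S)NCc1ccc(NS(C)(=O)=O)cc1` differs from compound 3 by methoxy in place of butyl on a saturated chain carbon, two bonds along the chain from an oxygen on an aromatic ring. This removes much of the chain that accompanied the large step from compound 2 to compound 3, so compound 4 is expected to show an 8.0-fold higher number from compound 3 to compound 4 (0.90 log units; beyond the scatter), a number higher than that of compound 3 yet probably not as high as that of compound 2. The estimate for compound 4 in this assay is 1200 nM, with a range from 350 nM to 4500 nM.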

Compound 4, half-maximal inhibitory concentration: 60 nM
Beside the measured number, compound 4's estimate is 20-fold (1.30 log units) above it; measured number below the stated range.
By their numbers in this assay, from the lowest: compound 4; then compound 3; then compound 2; then compound 1.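

In this assay, this position does not need the long hexyloxy chain: 2-methoxyethoxy in its place gives a 2.5-fold lower number from compound 3 to compound 4 (0.40 log units; beyond the scatter), so a shorter chain carrying an ether oxygen does better here. Measured from the small methoxy group, the same chain gives a 40-fold lower number from compound 2 to compound 4 (1.60 log units; beyond the scatter). Nothing available explains this gain.

Whether the ether oxygen or the shorter chain accounts for the change stays open, and a plain butoxy chain would help separate the two. An amine at the chain's end, or a longer chain with more ether oxygens, would show how far this change can be taken.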